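Swapping phenoxy for methyl on a seven-membered ring

The source may report more compounds than this note shows. Statements on the series, on what has been measured and on what is new or still open speak of the compounds shown alone.

Three compounds sharing a core built around a seven-membered aromatic ring of carbon only have been tested in a functional assay on the whole organism (strain Sprague-Dawley CD) for inhibition, with Rattus norvegicus as the target, read by paw edema, at a dose of 100 mg/kg by the oral route; on this read-out higher numbers stand for a stronger effect at the one dose given and lower numbers for a weaker effect. Compound 1 `CCOC(=O)C(=O)Nc1c(Oc2ccccc2)ccccc1=O` gives 20% in this assay. Compound 3 `CCOC(=O)C(=O)Nc1c(C)ccccc1=O` gives 37% in this assay. Compound 2 `CCOC(=O)C(=O)Nc1ccccc(Oc2ccccc2)c1=O` gives 9% in this assay, the lowest of the three numbers. Compound 2 and compound 1 contain the same atoms joined differently, and the difference between the two cores is not broken down here.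

The change from compound 1 to compound 3 is methyl in place of phenoxy on an aromatic carbon. This produced a number 17 percentage points higher from compound 1 to compound 3 (beyond the scatter).

Compound 4 `CCOC(=O)C(=O)Nc1ccccc(C)c1=O` has not yet been measured in this assay. Its relationship to compound 2 is the same kind of change, (methyl in place of phenoxy on an aromatic carbon), and this change occurs two times in all among the compounds shown. The surroundings differ: in the step from compound 1 to compound 3 the methyl sits next to the ring atom that bears a group of 8 heavy atoms, whereas in compound 4 it sits two ring bonds from that ring atom.

For compound 4 a step of a number 15 percentage points higher from compound 2 to compound 4 (beyond the scatter) is expected, resting on the rise seen in a number 17 percentage points higher from compound 1 to compound 3 (beyond the scatter) together with the starting point of compound 2 at 9%. Compound 4 is therefore estimated to give 24% in this assay, within a range from 5% to 45%, with the wider range reflecting the different place of the change.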

Compound 4, a percentage reported as inhibition, in the whole organism at one dose (the size of the read-out at that dose, not a potency): 34%
Compound 4: middle estimate off by 10 percentage points, on the low side; the measured number falls inside the stated range.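

In this assay, putting methyl in place of phenoxy gave a number 25 percentage points higher from compound 2 to compound 4 (beyond the scatter), so the rise seen on one core also appears on the other. Set side by side, the two steps go the same way and cannot be told apart in size, even though the change sits in a different place on the ring in each pair: the same change on two cores in this assay, a number 17 percentage points higher (beyond the scatter) from compound 1 to compound 3 and a number 25 percentage points higher (beyond the scatter) from compound 2 to compound 4, 8 percentage points apart, within the scatter of two such steps. This supports carrying the change between these two cores at this one oral dose, but two pairs make no general rule for other cores, and a percentage at a single dose is not a potency and does not explain why the number rises.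

Only phenoxy and methyl appear at these ring positions, so a methoxy, an ethyl or a plain hydrogen would be needed to show whether the rise follows the removal of the phenoxy ring or depends on the methyl itself. The ethyl ester stays the same in all four compounds, which leaves open how a carboxylic acid or an amide at that end would behave in this assay.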